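Anilino replacement on the quinazoline-free shared core: methoxypyridinyl in compound 3

The source may hold more compounds than are shown below. What is called first, only, known or untested is meant among the compounds shown, and "the series" means these compounds.

Two members of the series have numbers. Compound 1 `CCS(=O)(=O)Nc1cc(-c2ccc3ncnc(Nc4ccc(OC(F)(F)F)cc4)c3c2)cnc1OC` gives 23700 nM in a functional assay on MCF7 cells (Homo sapiens) for cytotoxicity, read by sulforhodamine B assay, with a stated time of 72 h; on this read-out higher numbers stand for weaker inhibition and lower numbers for stronger inhibition. Going by the values given here, compound 2 `CCS(=O)(=O)Nc1cc(-c2ccc3ncnc(Nc4ccc(F)c(C(=O)OC)c4)c3c2)cnc1OC` gives 1150 nM in this assay, the lower of the two numbers, and the only measured step, a 21-fold lower number from compound 1 to compound 2 (1.31 log units; beyond the scatter), shows that the group on the aromatic nitrogen moves this read-out strongly. Compound 3 `CCS(=O)(=O)Nc1cc(-c2ccc3ncnc(Nc4ccc(OC)nc4)c3c2)cnc1OC` carries 6-methoxypyridin-3-yl in place of 4-fluoro-3-(methoxycarbonyl)phenyl on a nitrogen on an aromatic ring. Among the compounds with values here, no measured pair covers this exact exchange; the step from compound 1 to compound 2 is the only one that bears on it, and it says only that changes at this position can be large in either direction. Since compound 2 holds the lowest number and the fluoro and methoxycarbonyl groups that accompany it are both given up, a rise is expected rather than a fall: the step from compound 2 to compound 3 is estimated at a 5.2-fold higher number from compound 2 to compound 3 (0.72 log units; beyond the scatter) in this assay. Compound 3 is therefore expected to give about 6000 nM in this assay, with a plausible range from 1500 nM to 25000 nM.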

Compound 3, half-maximal inhibitory concentration: 3770 nM
Compound 3: middle estimate off by 1.6-fold (0.20 log units), on the high side; the measured number falls inside the stated range.
By their numbers in this assay, from the lowest: compound 2; then compound 3; then compound 1.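

In this assay the 6-methoxypyridin-3-yl group on the nitrogen on an aromatic ring gives a 6.3-fold lower number from compound 1 to compound 3 (0.80 log units; beyond the scatter) and so shows that the low end of the series does not depend on the fluoro and methoxycarbonyl groups alone. Set against the best group so far, the same exchange gives a 3.3-fold higher number from compound 2 to compound 3 (0.52 log units; beyond the scatter) and places the smaller group, a ring with one hetero atom and fewer heavy atoms, in the middle of the three, with 4-fluoro-3-(methoxycarbonyl)phenyl still holding the lowest number and 4-(trifluoromethoxy)phenyl the highest. Nothing on hand accounts for this order of the three groups.

The compounds shown do not separate the fluoro group from the methoxycarbonyl group in compound 2, nor the ring nitrogen from the methoxy group in compound 3, as each exchange changes several features at once. Also open, going by these compounds, is how a carboxylic acid or a primary amide in place of the methoxycarbonyl group, or an amine in place of the methoxy group on the pyridine ring, would read in this assay against these three numbers.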